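Swapping a urea for a plain benzamide

This account rests on a few compounds, and the source may have more. Where it says the series, first, only, none or still open, it means among the compounds named here.

In a functional assay on SF-295 cells (Homo sapiens) for inhibition, read by sulforhodamine B assay, with a stated time of 48 h (a lower number here means a stronger inhibitor, a higher number a weaker inhibitor), compound 3 `COc1cc(-c2nn(-c3cccc(NC(=O)Nc4cccc(C(F)(F)F)c4)c3)cc2-c2ccncc2)ccc1Cl` gives 310 nM, the lowest of the two numbers shown. Compound 2 `COc1cc(-c2nn(-c3cccc(NC(=O)c4cccc(C(F)(F)F)c4)c3)cc2-c2ccncc2)ccc1Cl` gives 1020 nM, while compound 1 `O=C(Nc1cccc(-n2cc(-c3ccncc3)c(-c3ccc(Cl)c(O)c3)n2)c1)Nc1ccc(Cl)c(Cl)c1` has "not determined" (no result reported). For the measured compounds named here, the only measured step, a 3.3-fold lower number from compound 2 to compound 3 (0.52 log units; beyond the scatter), sets (3-(trifluoromethyl)phenyl)amino in place of 3-(trifluoromethyl)phenyl on a carbonyl carbon. Compound 4 `COc1cc(-c2nn(-c3cccc(NC(=O)c4ccccc4)c3)cc2-c2ccncc2)ccc1Cl` undoes that move and goes further: phenyl in place of (3-(trifluoromethyl)phenyl)amino on a carbonyl carbon. The step in this assay from compound 3 to compound 4 is therefore expected to run opposite to the measured step and to be of similar size; no measurement shows how losing the trifluoromethyl group alone matters, so the range is wide. Compound 4 is expected to give about 1200 nM, between 400 nM and 4000 nM, an expected step of a 3.9-fold higher number from compound 3 to compound 4 (0.59 log units; beyond the scatter).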

Compound 4, half-maximal inhibitory concentration: 340 nM
Estimate against measurement, compound 4: 3.5-fold (0.55 log units) above; measured number outside the range, below it.
By their numbers in this assay, from the lowest: compounds 3 and 4 (each within the scatter of the next); then compound 2.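

In this assay the plain benzamide need not be poorer than the urea: phenyl in place of (3-(trifluoromethyl)phenyl)amino on a carbonyl carbon gives a 1.1-fold higher number from compound 3 to compound 4 (0.04 log units; within the scatter) and so no real difference. Among the benzamides, hydrogen in place of trifluoromethyl on an aromatic carbon gives a 3.0-fold lower number from compound 2 to compound 4 (0.48 log units; beyond the scatter), so the earlier gain from the urea appears only against the trifluoromethyl benzamide. No supporting data explain either result.

Still open, on these data alone, is how a urea ending in plain phenyl compares with compound 4. Also open, as far as these compounds go, is whether a nitrile or a carboxylic acid on that aromatic carbon would track hydrogen or trifluoromethyl.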